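The compounds below may be only part of what the source reports. "The series", "measured", "known", "first", "only" and "open" are said of these compounds alone.

Measured in a functional assay on KYSE-70 cells for antiproliferative activity against KYSE-70 cell line (Homo sapiens), read by MTT assay, with a stated time of 72 h; a lower number here means a stronger inhibitor, a higher number a weaker inhibitor:
- compound 1 `O=C(Nc1cc(F)cc(F)c1)c1cc(=O)[nH]c2cc(Br)ccc12`: 10700 nM
- compound 2 `O=C(Nc1cc(F)cc(F)c1)c1cc(=O)[nH]c2cc(Cl)ccc12`: 9000 nM
- compound 3 `O=C(Nc1cc(F)cc(F)c1)c1cc(=O)[nH]c2cc(C(F)(F)F)ccc12`: 14200 nM

Compound 3 stands level with the other two within the scatter, with a 1.3-fold higher number from compound 1 to compound 3 (0.12 log units; within the scatter) and a 1.6-fold higher number from compound 2 to compound 3 (0.20 log units; within the scatter). The next compound is compound 4 `COc1ccc2c(C(=O)Nc3cc(F)cc(F)c3)cc(=O)[nH]c2c1`, and the change is methoxy in place of trifluoromethyl on an aromatic carbon.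

For the measured compounds named here, the steps that bear on it are the three exchanges at this same place: the two above and a 1.2-fold lower number from compound 1 to compound 2 (0.08 log units; within the scatter). All three lie within the scatter, so bromo, chloro and trifluoromethyl cannot be told apart in this assay. None of these steps involves methoxy, so the data offer only an indirect guide, and the range has to stay wide. No step beyond the scatter is expected in either direction, and the expected step is a 1.2-fold lower number from compound 3 to compound 4 (0.09 log units; within the scatter). For compound 4 the estimated value is 11500 nM, with an expected range of 5500 nM to 25000 nM.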

Compound 4, half-maximal inhibitory concentration: > 20000 nM
Compound 4: only a limit was reported; the forecaster's own chance of this, stated with the estimate: 8%; middle value at least 1.7-fold (0.24 log units) away from the limit.
By their numbers in this assay, from the lowest: compounds 2, 1 and 3 (each within the scatter of the next). At a limit, above all of these: compound 4.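

In this assay, compound 4 is reported only as a limit: the limit of > 20000 nM in this assay, at which 1 of the 4 values shown sits.

Methoxy gives the first exchange at this aromatic carbon that clears the scatter, with an at least 2.2-fold higher number from compound 2 to compound 4 (0.34 log units; beyond the scatter), whereas the floors of an at least 1.8-fold higher number from compound 1 to compound 4 (0.27 log units; that floor lies within the scatter) and an at least 1.4-fold higher number from compound 3 to compound 4 (0.14 log units; that floor lies within the scatter) do not clear it. The position is therefore not fully indifferent to its substituent: bromo, chloro and trifluoromethyl could not be told apart, but methoxy separates from chloro, and from bromo and trifluoromethyl only possibly.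

Going by these compounds, how far the number for compound 4 lies past its limit remains unknown, so the full size of these steps stays open. Also open, on these data alone, is whether methoxy stands alone at this carbon, or whether an amine or a hydroxyl, which could be set against methoxy here, would group with it or with the halogens.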